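The source may report more compounds than this note shows. Statements on the series, on what has been measured and on what is new or still open speak of the compounds shown alone.

In an ADME assay on L1210/0 cells (Mus musculus) for cytotoxicity, with a stated time of 48 h (on this read-out lower numbers stand for stronger inhibition and higher numbers for weaker inhibition), compound 1 (`CCCCCC#Cc1cn([C@H]2C[C@H](O)[C@@H](CO)O2)c(=O)[nH]c1=O`) gives > 200000 nM, which is a limit of the assay and not a number. Compound 2 (`CCCCC#Cc1cn([C@H]2C[C@H](O)[C@@H](CO)O2)c(=O)[nH]c1=O`) gives > 200000 nM, again a limit and not a number. It therefore stands at the limit of > 200000 nM in this assay, at which 2 of the 2 values shown sit, with no measured value on either side of it. Compound 3 (`CCCCCCc1cn([C@H]2C[C@H](O)[C@@H](CO)O2)c(=O)[nH]c1=O`) keeps the shared core and changes one group: hexyl in place of hex-1-yn-1-yl on an aromatic carbon. The triple bond outside aromatic rings is lost, on the aromatic carbon that carries the chain. Within the data shown here, the only measured step is a step that the two limits leave unreadable from compound 1 to compound 2, a change elsewhere in the chain, so it offers no size to carry over. No step in either direction beyond the scatter can be argued in this assay, and compound 3 is expected to remain near that limit. The expected change is a step that the limit leaves unreadable from compound 2 to compound 3. For compound 3 the estimate is 220000 nM, within an expected range from 80000 nM to 400000 nM.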

Compound 3, half-maximal inhibitory concentration: > 200000 nM
Compound 3: only a limit was reported; the forecaster's own chance of this, stated with the estimate: 75%; the middle value lies beyond the limit too.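

In this assay compound 3 gives > 200000 nM, again a limit and not a number, so no new step can be read between compound 3 and either compound 1 or compound 2. The compounds shown leave open how any of them would compare with the others, since all rest at one value: the limit of > 200000 nM in this assay, at which 3 of the 3 values shown sit.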